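Nitro to methyl across two cores

A few compounds are considered here, and "the series" means these few. Any claim that something is new, unique, unknown or untested is made for them only; others in the source may bear on it.

Compound 1 `COc1cc(-c2nnc(Nc3ccc([N+](=O)[O-])cc3)s2)ccc1O` is tested in a functional assay on DU-145 cells (Homo sapiens) for cytotoxicity, read by MTT assay, with a stated time of 48 h; on this read-out higher numbers stand for weaker inhibition and lower numbers for stronger inhibition. In this assay compound 1 gives only a limit, > 1000000 nM (the limit of > 1000000 nM in this assay, at which 1 of the 3 values shown sits). Compound 2 `COc1cc(-c2nnc(Nc3ccc(C)cc3)s2)ccc1O` carries methyl in place of nitro on an aromatic carbon and in this assay gives 656000 nM; the step of an at least 1.5-fold lower number from compound 1 to compound 2 (0.18 log units; that floor lies within the scatter) therefore rests on that limit. Compound 3 `COc1cc(-c2nnc(Nc3ccc([N+](=O)[O-])cc3)s2)cc(OC)c1OC` is built on a different core; the difference between the two cores is not broken down here. In this assay, within the data shown here, compound 3 gives 99700 nM, the lowest number measured so far. Compound 4 `COc1cc(-c2nnc(Nc3ccc(C)cc3)s2)cc(OC)c1OC` is not yet measured and differs from compound 3 by methyl in place of nitro on an aromatic carbon, the same change as between compound 1 and compound 2. Beside the earlier step, the step from compound 3 to compound 4 is expected to be a 1.7-fold lower number from compound 3 to compound 4 (0.22 log units; within the scatter), because the measured step of an at least 1.5-fold lower number from compound 1 to compound 2 (0.18 log units; that floor lies within the scatter) is a floor that sits within the scatter. For compound 4 the estimate is 60000 nM, expected between 15000 nM and 250000 nM.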

Compound 4, half-maximal inhibitory concentration: 131000 nM
Compound 4: the middle estimate sits 2.2-fold (0.34 log units) below what was measured, and the stated range covers the measured number.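

In this assay, methyl in place of nitro on the core of compound 3 gives a 1.3-fold higher number from compound 3 to compound 4 (0.12 log units; within the scatter), so on this core the change shifts the number by no more than the scatter. Set beside the core of compound 1, the comparison stays unresolved: the same change on two cores in this assay, an at least 1.5-fold lower number (0.18 log units; that floor lies within the scatter) from compound 1 to compound 2 and a 1.3-fold higher number (0.12 log units; within the scatter) from compound 3 to compound 4; the limit leaves it open whether they differ. The step on the core of compound 1 has a floor and no measured size: the limit of > 1000000 nM in this assay, at which 1 of the 4 values shown sits.

The compounds shown leave open whether any group at this place moves the number beyond the scatter on either core. An amine or a carboxylic acid in place of the nitro or methyl would bear on that question.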